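A few compounds are considered here, and "the series" means these few. Any claim that something is new, unique, unknown or untested is made for them only; others in the source may bear on it.

Measured in a functional assay on HL-60 cells (Homo sapiens) for antiproliferative activity, read by MTT assay, with a stated time of 72 h; on this read-out lower numbers stand for stronger inhibition and higher numbers for weaker inhibition:
- compound 1 `NC1=NC2(CCOCC2)N(OCCCOc2ccccc2Cl)C(N)=N1`: 660 nM
- compound 2 `Cc1cc(C)cc(OCCCON2C(N)=NC(N)=NC23CCOCC3)c1`: 720 nM
- compound 3 `NC1=NC2(CCSCC2)N(OCCCOc2cccc(Cl)c2Cl)C(N)=N1`: 30 nM

Compound 2 at 720 nM sits at the high end of these numbers, not separated from compound 1 at 660 nM. Compound 3 at 30 nM lies clearly lower than both.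

Compound 4 `NC1=NC2(CCOCC2)N(OCCCOc2cccc(Cl)c2)C(N)=N1` keeps the core of compound 2 and has 3-chlorophenyl in place of 3,5-dimethylphenyl on an oxygen on a saturated carbon. Within the data shown here, the one measured step that bears on this change is a 1.1-fold higher number from compound 1 to compound 2 (0.04 log units; within the scatter), which swapped 2-chlorophenyl for 3,5-dimethylphenyl at the same place and stayed within the scatter. Compound 3 differs in both the core and the group on that oxygen, so it is not used here. No step beyond the scatter is therefore expected in this assay, and the estimate is a 1.3-fold lower number from compound 2 to compound 4 (0.12 log units; within the scatter). For compound 4 the expected value is 550 nM, with an estimated range from 220 nM to 1300 nM.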

Compound 4, half-maximal inhibitory concentration: 520 nM
Compound 4: the middle estimate sits 1.1-fold (0.02 log units) above what was measured; measured number inside the range.
By their numbers in this assay, from the lowest: compound 3; then compounds 4, 1 and 2 (each within the scatter of the next).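

In this assay, the group on an oxygen on a saturated carbon now has three readings on the shared core: 3-chlorophenyl in place of 3,5-dimethylphenyl gives a 1.4-fold lower number from compound 2 to compound 4 (0.14 log units; within the scatter), and 3-chlorophenyl in place of 2-chlorophenyl gives a 1.3-fold lower number from compound 1 to compound 4 (0.10 log units; within the scatter). Neither step separates the compounds, so for these three groups this place shows no change beyond the scatter, including when the chlorine-bearing phenyl group is 3-chlorophenyl rather than 2-chlorophenyl. No measured evidence is available to explain this result.

Compound 3 at 30 nM differs from the others in both the core and the group on that oxygen, so its value cannot be assigned to either change alone. Going by these compounds, whether an amine or a carboxylic acid on the phenyl ring, or a longer chain in place of the present one, would also stay within the scatter remains open.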